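Shortening the chain on the shared core

The compounds below may be only part of what the source reports. "The series", "measured", "known", "first", "only" and "open" are said of these compounds alone.

Compound 2, `CCS(=O)(=O)CCCCC12CCC(c3nnc(-c4ccccc4C(F)(F)F)n3C)(CC1)CC2`, stands lowest of the two numbers in a functional assay on the whole organism (strain ICR) for inhibition, with Mus musculus as the target, with a stated time of 16 h, at a dose of 10 mg/kg by the oral route (a higher number here means more inhibition at the dose given (going by the name of the read-out), a lower number less inhibition), giving 58%. Compound 1, `CCSCCC12CCC(c3nnc(-c4ccccc4C(F)(F)F)n3C)(CC1)CC2`, gives 72% in this assay. Going by the values given here, the one measured step, a number 14 percentage points lower from compound 1 to compound 2 (beyond the scatter), is the only precedent. Compound 3, `CCOCC12CCC(c3nnc(-c4ccccc4C(F)(F)F)n3C)(CC1)CC2`, differs from compound 2 by ethoxy in place of 3-(ethylsulfonyl)propyl on a saturated chain carbon bound to a saturated ring carbon. Among the compounds with values here, no measured step covers a shortening of this chain, so that precedent bears on it only loosely. The step expected is a number 7 percentage points higher from compound 2 to compound 3 (within the scatter), back toward the number of compound 1. Compound 3 is therefore estimated at 65%, within 45% to 85%.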

Compound 3, a percentage reported as inhibition, in the whole organism at one dose (the size of the read-out at that dose, not a potency): 3%
The estimate for compound 3 lay 62 percentage points above the measured number; the whole stated range lies above it.
By their numbers in this assay, from the lowest: compound 3; then compound 2; then compound 1.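

In this assay the change to ethoxy on this saturated chain carbon carries a far larger penalty than the earlier change between sulfur-bearing chains, with a number 55 percentage points lower from compound 2 to compound 3 (beyond the scatter) and a number 69 percentage points lower from compound 1 to compound 3 (beyond the scatter) as well. Across these three compounds, both sulfur-bearing chains keep substantial inhibition at the dose given, while ethoxy keeps very little. No available evidence explains this loss.

As far as these compounds go, it remains open whether the loss goes with the chain's oxygen or with its length. A longer ether such as 3-ethoxypropyl, or an amine at this position, would help separate these.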